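Cinnamamide ureas: morpholine amide on the methyl-branched chain

The source may hold more compounds than are shown below. What is called first, only, known or untested is meant among the compounds shown, and "the series" means these compounds.

The shared core is a diaryl urea carrying a propenoyl chain on one ring. Compound 1 `CNC(=O)/C=C/c1ccc(NC(=O)Nc2ccc(Cl)c(C(F)(F)F)c2)cc1` is the methylamide of the unbranched chain; in a functional assay on KETR3 cells (Homo sapiens) for inhibition, read by MTT assay, with a stated time of 120 h (on this read-out higher numbers stand for weaker inhibition and lower numbers for stronger inhibition), compound 1 gives 21200 nM. Compound 2 `CNC(=O)/C(C)=C/c1ccc(NC(=O)Nc2ccc(Cl)c(C(F)(F)F)c2)cc1` adds a methyl on the chain, the change being (2-(methylcarbamoyl)prop-1-en-1-yl in place of 2-(methylcarbamoyl)ethenyl on an aromatic carbon). In this assay compound 2 gives only a limit, > 50000 nM. The step is an at least 2.3-fold higher number from compound 1 to compound 2 (0.37 log units; beyond the scatter). Compound 3 `CC1CN(C(=O)/C=C/c2ccc(NC(=O)Nc3ccc(Cl)c(C(F)(F)F)c3)cc2)CC(C)O1` keeps the unbranched chain but replaces the methylamide, the change being (2,6-dimethylmorpholin-4-yl in place of methylamino on a carbonyl carbon). In this assay compound 3 likewise gives only a limit, > 50000 nM. The step is an at least 2.3-fold higher number from compound 1 to compound 3 (0.37 log units; beyond the scatter). Both weakened compounds sit at the limit of > 50000 nM in this assay, at which 2 of the 3 values shown sit, so neither step has a measured upper end.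

Compound 4 `C/C(=C\c1ccc(NC(=O)Nc2ccc(Cl)c(C(F)(F)F)c2)cc1)C(=O)N1CC(C)OC(C)C1` is not yet measured. It differs from compound 2 by 2,6-dimethylmorpholin-4-yl in place of methylamino on a carbonyl carbon, the same change as from compound 1 to compound 3, and the place is the same in both cases. The two cores differ by 2-(methylcarbamoyl)prop-1-en-1-yl in place of 2-(methylcarbamoyl)ethenyl on an aromatic carbon.

For compound 4 in this assay the expected step is a step that the limit leaves unreadable from compound 2 to compound 4, set beside the measured at least 2.3-fold higher number from compound 1 to compound 3 (0.37 log units; beyond the scatter); this rests on compound 2 already standing at the limit > 50000 nM, and on the same change having taken compound 3 to a limit. Compound 4 is therefore expected to report only a limit as well, with an estimated value of 100000 nM, between 50000 nM and 300000 nM.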

Compound 4, half-maximal inhibitory concentration: > 50000 nM
Compound 4: a limit, no number (the forecaster's own chance of this, stated with the estimate: 85%); the middle value lies beyond the limit too.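

In this assay, among these compounds, compound 4 gives only a limit, > 50000 nM, and compound 2 also stands at a limit, so no step between compound 2 and compound 4 can be read. The series is crowded at this ceiling: the limit of > 50000 nM in this assay, at which 3 of the 4 values shown sit.

The compounds shown leave open how much activity, if any, compound 2, compound 3 and compound 4 retain, and whether they differ from one another.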